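Ester and five-membered ring changes on the shared core

The source may hold more compounds than are shown below. What is called first, only, known or untested is meant among the compounds shown, and "the series" means these compounds.

Measured in an assay on membranes from HEK293 cells for displacement of a labelled ligand from adenosine receptor A2b (Homo sapiens), read by scintillation counting, with a stated time of 30 min; a lower number here means a stronger inhibitor, a higher number a weaker inhibitor:
compound 1 `CC1=C(C(=O)OCC(C)C)C(c2cccs2)NC(=O)N1`: 2130 nM
compound 2 `CC1=C(C(=O)OCc2ccccc2)C(c2cccs2)NC(=O)N1`: 1920 nM
compound 3 `CC1=C(C(=O)OCC2CCC2)C(c2ccoc2)NC(=O)N1`: 739 nM

Compound 3 stands lowest of the three numbers; compound 2 is nearest, with a higher number beyond the scatter, and compound 1 furthest. Going by the values given here, the only single-point step measured so far, a 1.1-fold lower number from compound 1 to compound 2 (0.05 log units; within the scatter), concerns the ester group and is within the scatter; it does not bear on the five-membered ring.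

Compound 4 `CC1=C(C(=O)OCC2CCC2)C(c2cccs2)NC(=O)N1` differs from compound 3 by thiophen-2-yl in place of furan-3-yl on a saturated ring carbon. Among the compounds with values here, no measured pair isolates this change: compound 1 and compound 2 carry thiophen-2-yl but with other esters, and compound 3 is the only furan-3-yl compound, so the gap between compound 3 and the other two cannot be assigned to the ring or the ester. Compound 4 is therefore expected to lie between the values of compound 3 and compound 2, with wide uncertainty, an expected step of a 1.6-fold higher number from compound 3 to compound 4 (0.21 log units; within the scatter). The estimate for compound 4 in this assay is 1200 nM, in the range 400 nM to 3500 nM.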

Compound 4, inhibition constant: 2840 nM
Estimate against measurement, compound 4: 2.4-fold (0.37 log units) below; the range from low to high includes it.
By their numbers in this assay, from the lowest: compound 3; then compounds 2, 1 and 4 (each within the scatter of the next).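

With the cyclobutyl ester held fixed in this assay, the change of furan-3-yl to thiophen-2-yl on the saturated ring carbon can now be read alone: a 3.8-fold higher number from compound 3 to compound 4 (0.58 log units; beyond the scatter), although the two groups match in ring size, heavy-atom count and hydrogen-bond counts. The ester changes with thiophen-2-yl held fixed stay small, a 1.5-fold higher number from compound 2 to compound 4 (0.17 log units; within the scatter) and a 1.3-fold higher number from compound 1 to compound 4 (0.12 log units; within the scatter), so the lower number of compound 3 goes with furan-3-yl, not with the cyclobutyl ester. Nothing available explains the difference between the two rings.

Going by these compounds alone, compound 3 remains the only furan-3-yl example, so it is open whether the ring step holds with the phenyl or isopropyl esters. Also open, on these data alone, is what furan-2-yl or thiophen-3-yl gives at this carbon, and what a longer ester chain gives.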